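Dropping the chloro from compound 3

A few compounds are considered here, and "the series" means these few. Any claim that something is new, unique, unknown or untested is made for them only; others in the source may bear on it.

The measured compounds:
Compound 1, `Cc1sc2ccccc2c1C1C=CN=CN1C`, 30 mg/kg
Compound 2, `Cc1sc2ccc(Cl)cc2c1C1C=CN=CN1`, 3 mg/kg
Compound 3, `Cc1sc2c(Cl)cccc2c1C1C=CN=CN1`, 30 mg/kg

All three were tested in a functional assay on the whole organism with Mus musculus as the target, with a stated time of 15 min; a higher number here means that more compound is needed for the effect, a lower number that less compound is needed. Compound 3 gives 30 mg/kg, a number level with that of compound 1, which gives 30 mg/kg; these two are the highest of the three, and the gap between them lies within the scatter. For the measured compounds named here, compound 2 stands apart: it gives 3 mg/kg, a difference from compound 3 that lies beyond the scatter, though no single-point step connects the two.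

Compound 4, `Cc1sc2ccccc2c1C1C=CN=CN1`, has not yet been measured. It differs from compound 3 by hydrogen in place of chloro on an aromatic carbon.

Going by the values given here, no step between measured compounds removes a chloro in this way, so there is no direct guide. With nothing else to lean on, the expected step of no change at the digits printed from compound 3 to compound 4 (within the scatter) is none beyond the scatter. Compound 4 is therefore estimated at 30 mg/kg, within a range of 10 mg/kg to 100 mg/kg.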

Compound 4, minimum effective dose: 3 mg/kg
Estimate against measurement, compound 4: 10-fold (1.00 log units) above; the whole stated range lies above it.
By their numbers in this assay, from the lowest: compounds 2 and 4 (each within the scatter of the next); then compounds 1 and 3 (each within the scatter of the next).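

In this assay, for the compounds shown here, hydrogen in place of chloro on this aromatic carbon gives a 10-fold lower number from compound 3 to compound 4 (1.00 log units; beyond the scatter) and so shows for the first time that a chloro here goes with needing more compound. The same kind of swap from the chloro placed elsewhere on this ring in compound 2 gives no change at the digits printed from compound 2 to compound 4 (within the scatter) and shows that, across these three compounds, the outcome depends on where the chloro sits. Hydrogen in place of methyl on the amine nitrogen in the ring gives a 10-fold lower number from compound 1 to compound 4 (1.00 log units; beyond the scatter) as well, so that nitrogen is a second place where a single small change matters.

Nothing shown here explains these steps. Going by these compounds, it remains open whether a fluoro, a methoxy or a nitrile on this aromatic carbon would match the chloro or the hydrogen, and whether an ethyl on the ring nitrogen would match the methyl.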